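A Sulfur-Bearing Ring Enters the Series

This account rests on a few compounds, and the source may have more. Where it says the series, first, only, none or still open, it means among the compounds named here.

Measured in a physicochemical assay for solubility, in phosphate buffer, measured as kinetic solubility; on this read-out lower numbers stand for lower solubility and higher numbers for higher solubility:
Compound 1 `CC(C)C(/C=C1\NC(=O)NC1=O)c1ccc(-c2ccc3cccc(F)c3c2)[nH]c1=O` gives 10700 nM
Compound 2 `Cc1cc(C(/C=C2\OC(=O)NC2=O)C(C)C)c(=O)[nH]c1-c1ccc2cccc(F)c2c1` gives 35700 nM
Compound 3 `CC(C)[C@H](C[C@H]1OC(=O)NC1=O)c1ccc(-c2ccc3cccc(F)c3c2)[nH]c1=O` gives 35400 nM

Compound 1 stands lowest of the three in this assay, and both other compounds lie above it by more than the usual scatter. The values of compound 2 and compound 3 lie within scatter of each other.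

Compound 4 `CC(C)C(/C=C1\SC(=O)NC1=O)c1ccc(-c2ccc3cccc(F)c3c2)[nH]c1=O` is the next to be measured. It differs from compound 1 in one place: a group of 8 heavy atoms (4 carbon, 1 nitrogen, 2 oxygen, 1 sulfur; one five-membered non-aromatic ring with 2 hetero atoms) in place of a group of 8 heavy atoms (4 carbon, 2 nitrogen, 2 oxygen; one five-membered non-aromatic ring with 2 hetero atoms), on a saturated chain carbon bound to an aromatic carbon and a saturated chain carbon. The entering group holds a sulfur atom, which the leaving group lacks.

Going by the values given here, no measured pair isolates this exchange, so the expectation rests on weak ground. Compound 2 at 35700 nM and compound 3 at 35400 nM each differ from compound 1 in more than one place, and they offer only loose guidance toward a higher number. The expected step is a 2.2-fold higher number from compound 1 to compound 4 (0.35 log units; beyond the scatter), upward and of moderate size. For compound 4 the estimated value is 24000 nM, with an expected range from 9000 nM to 60000 nM.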

Compound 4, solubility: 25600 nM
Compound 4: middle estimate off by 1.1-fold (0.03 log units), on the low side; low and high end bracket the measured number.
By their numbers in this assay, from the lowest: compound 1; then compounds 4, 3 and 2 (each within the scatter of the next).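

In this assay, going by these compounds alone, the sulfur-bearing ring in place of the ring with 2 nitrogen atoms, on a saturated chain carbon bound to an aromatic carbon and a saturated chain carbon, gives a 2.4-fold higher number from compound 1 to compound 4 (0.38 log units; beyond the scatter), the first comparison that differs in one place. At this position, then, the read-out responds to an exchange that leaves the heavy-atom count at 8 and moves the group from 2 hydrogen-bond donors and 2 acceptors to 1 donor and 3 acceptors. Nothing at hand bears on what lies behind this step.

From the compounds shown here alone, it remains open how the oxygen-bearing ring of compound 2 and compound 3 would read on the unchanged core of compound 4. Also open, going by these compounds, is how an amine or a carboxylic acid would read in place of the ring at this carbon.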